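This account rests on a few compounds, and the source may have more. Where it says the series, first, only, none or still open, it means among the compounds named here.

Measured compounds:
compound 1 `O=C(CCC1=CCCN(Cc2ccc(F)cc2)C1=O)NO`: 9960 nM
compound 2 `O=C(CCC1=CCCN(CCCc2ccc(-c3ccccc3)cc2)C1=O)NO`: 3190 nM
compound 3 `O=C(CCC1=CCCN(CCCCc2cccc3ccccc23)C1=O)NO`: 1670 nM

All three were tested in a functional assay on HCT-15 cells (Homo sapiens) for inhibition, read by sulforhodamine B assay; a lower number here means a stronger inhibitor of growth, a higher number a weaker inhibitor of growth. Compound 1 stands at the highest of the three numbers; its gaps to compound 2 and to compound 3 both lie beyond the scatter, so compound 1 is the weakest growth inhibitor of the set. Compound 4 `Cc1ccc(CN2CCC=C(CCC(=O)NO)C2=O)cc1` has not yet been measured. It differs from compound 1 in one place: methyl in place of fluoro on an aromatic carbon. Among the compounds with values here, no measured pair shows this change, so the data offer no guide to its size. One expects the step of a 1.2-fold lower number from compound 1 to compound 4 (0.10 log units; within the scatter) to be small, with no change beyond the scatter. Compound 4 is therefore estimated at 8000 nM, in the range 3500 nM to 18000 nM.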

Compound 4, concentration for 50% growth inhibition: 8510 nM
For compound 4 the middle estimate is 1.1-fold (0.03 log units) below the measured one, within the range that was stated.
By their numbers in this assay, from the lowest: compounds 3 and 2 (each within the scatter of the next); then compounds 4 and 1 (each within the scatter of the next).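

In this assay, methyl in place of fluoro on an aromatic carbon, para to a large group, gives a 1.2-fold lower number from compound 1 to compound 4 (0.07 log units; within the scatter) and so leaves growth inhibition unchanged within the scatter. Within the data shown here, this is the first comparison in the set between compounds that differ in one place, and it shows that this position accepts either group. Nothing available explains this result. As far as these compounds go, whether an amine or a carboxylic acid in this place would also leave the number unchanged remains open. So does whether a longer chain on the ring nitrogen would change how this position responds.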